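The source may hold more compounds than are shown below. What is called first, only, known or untested is meant among the compounds shown, and "the series" means these compounds.

Compound 1 `COc1c(C)c(/C=C/C(=O)O)oc(=O)c1CO`: > 50000 nM
Compound 2 `COc1c(CO)c(/C=C/C(=O)O)oc(=O)c1CO`: > 50000 nM

Both compounds were tested in a functional assay on HCT-116 cells (Homo sapiens) for cytotoxicity; a lower number here means a stronger inhibitor, a higher number a weaker inhibitor. Compound 1 gives > 50000 nM, which is a limit and not a number. Compound 2 gives > 50000 nM, also a limit. All that can be said so far is the limit of > 50000 nM in this assay, at which 2 of the 2 values shown sit.

The next compound, compound 3 `COc1c(C)c(/C=C/C(=O)O)oc(=O)c1C`, has not yet been measured. It differs from compound 1 as follows: hydrogen in place of hydroxy on a saturated chain carbon bound to an aromatic carbon. In short, hydroxymethyl becomes methyl.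

For the measured compounds named here, only one measured step bears on this: a step that the two limits leave unreadable from compound 1 to compound 2. That step places a hydroxy on the same kind of carbon, so it is the opposite kind of change. With limits at both ends, it gives no size and no direction to carry over.

Compound 1 offers only a limit as a starting point, so no real shift is expected in this assay, and another limit is the likeliest result. The estimated step that the limit leaves unreadable from compound 1 to compound 3 is expected to stay within the scatter. For compound 3 the expected value is 60000 nM, with an estimated range of 25000 nM to 120000 nM.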

Compound 3, half-maximal inhibitory concentration: > 50000 nM
Compound 3: only a limit was reported; the forecaster's own chance of this, stated with the estimate: 85%; the middle value does not contradict the limit.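

In this assay compound 3 gives > 50000 nM, which is a limit and not a number. Compound 1 also has only a limit, so no step can be read between compound 1 and compound 3. The compounds shown leave open how hydroxymethyl and methyl compare on the shared core, since every result is a limit: the limit of > 50000 nM in this assay, at which 3 of the 3 values shown sit.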